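Benzyl in place of methyl on the shared core

This account rests on a few compounds, and the source may have more. Where it says the series, first, only, none or still open, it means among the compounds named here.

Compound 1 `COC(=O)/C=C\NC(=O)[C@H](O)C(C)(C)CO` has "not determined" (no result reported) in an ADME assay on WI-38 cells (Homo sapiens) for inhibition, read by CellTiter-Glo, with a stated time of 48 h, tested at 100 uM; on this read-out lower numbers stand for less inhibition and higher numbers for more inhibition at the one concentration tested (going by the name of the read-out); where it stands cannot be read from a number of its own. Two neighbours on the same core were measured: compound 2 `CCOC(=O)/C=C/NC(=O)[C@H](O)C(C)(C)CO` gives 36% in this assay, and compound 3 `CC(C)(C)OC(=O)/C=C/NC(=O)[C@@H](O)C(C)(C)CO` gives 14% in this assay. Compound 4 `CC(C)(CO)[C@@H](O)C(=O)N/C=C\C(=O)OCc1ccccc1` is the unmeasured step from compound 1: phenyl in place of hydrogen on a saturated chain carbon bound to an oxygen next to a carbonyl group. Going by the values given here, no measured step covers this change, so its size is open; a small move in either direction, within the scatter, is as likely as a clear one. Compound 4 is expected to give 30% in this assay, between 5% and 60%.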

Compound 4, a percentage reported as inhibition, at one concentration (the size of the read-out at that concentration, not a potency): 4%
Compound 4: middle estimate off by 26 percentage points, on the high side; measured number below the stated range.
By their numbers in this assay, from the lowest: compounds 4 and 3 (each within the scatter of the next); then compound 2.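

Going by these compounds alone, compound 1 has no number in this assay, and no step from it to compound 4 can be read. No measured evidence bears on this result. The compounds shown leave open how large the methyl to benzyl change is.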